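A few compounds are considered here, and "the series" means these few. Any claim that something is new, unique, unknown or untested is made for them only; others in the source may bear on it.

Compounds measured in an ADME assay on the whole organism (plasma, Rattus norvegicus, strain Sprague-Dawley) for protein binding, read by LC-MS, with a stated time of 24 h; on this read-out lower numbers stand for a smaller free fraction and higher numbers for a larger free fraction:
compound 1, `Cc1cc(-c2nnn(C)c2COC(=O)N(C)CCC(C)C)ccc1O[C@H]1CCC[C@H](C(=O)O)C1`, gives 0.012
compound 2, `Cc1noc(-c2ccc(O[C@H]3CCC[C@H](C(=O)O)C3)cc2)c1COC(=O)N(C)C1CCCC1`, gives 0.002
compound 3, `CN(C(=O)OCc1c(-c2ccc(O[C@H]3CCC[C@H](C(=O)O)C3)cc2)cnn1C)C1CCCC1`, gives 0.009

Of these three, compound 2 stands lowest in this assay; compound 3 is the nearest to it and compound 1 the furthest, both gaps lying beyond the usual scatter. Compound 4, `Cc1noc(-c2ccc(O[C@H]3CCC[C@H](C(=O)O)C3)cc2)c1CNC(=O)OCCC(C)(C)C`, has not yet been measured. It differs from compound 2 in one place: a group of 10 heavy atoms (7 carbon, 1 nitrogen, 2 oxygen; no ring) in place of a group of 10 heavy atoms (7 carbon, 1 nitrogen, 2 oxygen; one five-membered non-aromatic ring of carbon only), on a saturated chain carbon bound to an aromatic carbon. Within the data shown here, no step between measured compounds isolates this kind of change, so the expected step of a 2.0-fold higher number from compound 2 to compound 4 (0.30 log units; within the scatter) is a modest rise in free fraction, near the edge of the scatter. Compound 4 is therefore estimated to give 0.004, within a range from 0.0015 to 0.012.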

Compound 4, unbound fraction: 0.001
Compound 4: the middle estimate sits 4.0-fold (0.60 log units) above what was measured; the measured number lies below the stated range.
By their numbers in this assay, from the lowest: compounds 4 and 2 (each within the scatter of the next); then compounds 3 and 1 (each within the scatter of the next).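

In this assay, among these compounds, the first step that isolates a single change, a 2.0-fold lower number from compound 2 to compound 4 (0.30 log units; within the scatter), shows that on a saturated chain carbon bound to an aromatic carbon, the group with one five-membered non-aromatic ring of carbon only can give way to a group with no ring and one hydrogen-bond donor without the free fraction leaving the usual scatter. Both groups hold the same count of heavy atoms, so this single step cannot separate the loss of the ring from the added donor. Nothing at hand explains the outcome.

Going by these compounds, whether a tertiary amine or a morpholine ring at this place would shift the free fraction beyond the scatter remains open. So does whether the same exchange would behave alike on the core of compound 3.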